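The source may report more compounds than this note shows. Statements on the series, on what has been measured and on what is new or still open speak of the compounds shown alone.

Measured so far:
compound 1 `O=C(CN1CCN(C(=O)c2cccc(Cl)c2)CC1)N1CCN(CCCc2c[nH]c3ccc(F)cc23)CC1` - 66200 nM
compound 2 `O=C(CN1CCN(C(=O)c2cccc(Br)c2)CC1)N1CCN(CCCc2c[nH]c3ccc(F)cc23)CC1` - 40600 nM

In an ADME assay on HEK293 cells (Homo sapiens) for cytotoxicity, read by MTT assay, with a stated time of 72 h (a lower number here means a stronger inhibitor, a higher number a weaker inhibitor), compound 2 gives 40600 nM and stands within the scatter of compound 1, whose value is 66200 nM on the same read-out. Compound 3 `O=C(CN1CCN(C(=O)c2ccccc2Br)CC1)N1CCN(CCCc2c[nH]c3ccc(F)cc23)CC1` carries 2-bromophenyl in place of 3-bromophenyl on a carbonyl carbon with the same atoms joined differently. For the measured compounds named here, the only measured step is a 1.6-fold lower number from compound 1 to compound 2 (0.21 log units; within the scatter) and it exchanges one halogen for another at an unchanged place, so it bears only loosely on this change. Going by the values given here, no measured step tests a shift of the bromine. No step beyond the scatter is therefore expected in this assay and no direction can be argued. The expected step is a 1.1-fold higher number from compound 2 to compound 3 (0.04 log units; within the scatter) and stays inside the scatter. The estimate for compound 3 is 45000 nM with an expected range from 20000 nM to 100000 nM on this read-out.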

Compound 3, half-maximal inhibitory concentration: 77100 nM
The estimate for compound 3 lay 1.7-fold (0.23 log units) below the measured number; the measured number falls inside the stated range.
By their numbers in this assay, from the lowest: compounds 2, 1 and 3 (each within the scatter of the next).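

In this assay the shift from 3-bromophenyl to 2-bromophenyl on the carbonyl carbon gives a 1.9-fold higher number from compound 2 to compound 3 (0.28 log units; within the scatter) and is the only step shown that moves the halogen without exchanging it. The change from 3-chlorophenyl to 2-bromophenyl at the same place, which alters both the halogen and its position, gives a 1.2-fold higher number from compound 1 to compound 3 (0.07 log units; within the scatter) and also stays inside the scatter. On this read-out, these halogen changes therefore do not separate the three compounds, and nothing available bears on a cause for either step.

Going by these compounds, it remains open whether any group at this place can produce a step beyond the scatter, and unsubstituted phenyl, methoxyphenyl, trifluoromethylphenyl or a carboxylic acid on the ring would test that. A longer chain elsewhere on the shared core is equally untested by these compounds.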